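The compounds below may be only part of what the source reports. "The series", "measured", "known", "first", "only" and "open" are said of these compounds alone.

Compound 1 `CCCCCCC(CCO)n1cnc2c(NC)ncnc21`: in a functional assay on SW480 cells (Homo sapiens) for antiproliferative activity, read by MTT assay, with a stated time of 48 h (a lower number here means a stronger inhibitor, a higher number a weaker inhibitor), compound 1 gives > 50000 nM, which is a limit of the assay rather than a number.
Compound 2 `CCCCCCC(CCO)n1cnc2c(N)ncnc21`: in this assay compound 2 gives > 50000 nM, again a limit.
Compound 3 `CCCCCCCCC(CCO)n1cnc2c(NC)ncnc21`: in this assay compound 3 gives 3770 nM.

Compound 4 `CCCCCCCCC(CCO)n1cnc2c(N(C)C)ncnc21` has not yet been measured in this assay. It is made from compound 3 by methyl in place of hydrogen on a nitrogen on an aromatic ring. The same kind of change separates compound 2 from compound 1, namely (methyl in place of hydrogen on a nitrogen on an aromatic ring), though the surroundings differ: in that pair the nitrogen's other neighbour is only an aromatic carbon, whereas in compound 4 it also carries a saturated chain carbon. That earlier step, a step that the two limits leave unreadable from compound 2 to compound 1, cannot be sized because of the limit of > 50000 nM in this assay, at which 2 of the 3 values shown sit. The difference between the cores of compound 2 and compound 3 is not broken down here. What is readable is an at least 13-fold lower number from compound 1 to compound 3 (1.12 log units; beyond the scatter), which shows how the chain, not the nitrogen, moves the number.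

For compound 4 the expected step is a 1.6-fold higher number from compound 3 to compound 4 (0.20 log units; within the scatter), a guess resting on the fact that the only comparable methylation, compound 2 to compound 1, left no readable size. Compound 4 is thus estimated at 6000 nM, between 1500 nM and 25000 nM.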

Compound 4, half-maximal inhibitory concentration: 21600 nM
For compound 4 the middle estimate is 3.6-fold (0.56 log units) below the measured one; the range from low to high includes it.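

In this assay, replacing a hydrogen with a methyl on the nitrogen on the aromatic ring, which turns methylamino into dimethylamino, gives a 5.7-fold higher number from compound 3 to compound 4 (0.76 log units; beyond the scatter). On the core of compound 3, then, this single added methyl makes the compound a weaker inhibitor by a modest but real margin. This does not show that the change behaves the same way on another core, since the only other example of it, on the core of compound 1, gives no size to compare, and one readable step is no trend; that earlier step cannot be read because of a shared limit: the limit of > 50000 nM in this assay, at which 2 of the 4 values shown sit.

From the compounds shown here alone, it remains open whether a larger group on the same nitrogen, such as ethyl or cyclopropyl, would move the number further in the same direction. Going by these compounds, it is also open whether a chain longer than that of compound 3 would keep the same penalty for the added methyl.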